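Chloro for hydrogen on the aromatic ring of compound 2

The compounds below may be only part of what the source reports. "The series", "measured", "known", "first", "only" and "open" are said of these compounds alone.

Compound 2 `C/C(C(=O)NC1CC1)=C(/C)c1ccccc1` and compound 1 `C/C(C(=O)NC1CC1)=C(/C)c1ccc(F)cc1` share a core and differ only on the aromatic ring. In a toxicity assay on the whole organism (strain Icem-CET (SPF Caw)) for cytotoxicity, with Mus musculus as the target (a lower number here means that less compound is needed, a higher number that more compound is needed for the effect), compound 1 gives 110 mg/kg, and compound 2 gives 100 mg/kg. Within the data shown here, compound 2 therefore holds the lowest of the two numbers so far, with compound 1 as its only neighbour; the change a 1.1-fold lower number from compound 1 to compound 2 (0.04 log units; within the scatter) is within the scatter, so the two compounds are not told apart by this assay.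

Compound 3 `C/C(C(=O)NC1CC1)=C(/C)c1ccc(Cl)cc1` has not yet been measured in this assay. It differs from compound 2 by chloro in place of hydrogen on an aromatic carbon. Among the measured compounds shown here, the only measured step that bears on it is the exchange of a halogen for hydrogen at the same place, from compound 1 to compound 2, and that step stayed within the scatter. On that basis no step beyond the scatter is expected for compound 3, and the value is estimated as a 1.1-fold higher number from compound 2 to compound 3 (0.04 log units; within the scatter), that is 110 mg/kg with a range from 60 mg/kg to 200 mg/kg.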

Compound 3, dose for half-maximal effect: 350 mg/kg
Beside the measured number, compound 3's estimate is 3.2-fold (0.50 log units) below it, and the stated range ends below it.
By their numbers in this assay, from the lowest: compounds 2 and 1 (each within the scatter of the next); then compound 3.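

In this assay this position, an aromatic carbon para to a large group, proves sensitive to the substituent it carries: chloro in place of hydrogen gives a 3.5-fold higher number from compound 2 to compound 3 (0.54 log units; beyond the scatter) and so goes beyond the scatter, which the exchange between fluoro and hydrogen at the same place did not do. Chloro in place of fluoro gives a 3.2-fold higher number from compound 1 to compound 3 (0.50 log units; beyond the scatter) as well, so the two halogens are told apart here, and a halogen at this place cannot be treated as a single kind of change. Both steps are modest and point the same way, with more compound needed for the effect once chloro is present, but nothing shown here explains why chloro separates from fluoro and hydrogen.

With only hydrogen, fluoro and chloro at this place, the compounds shown leave open whether bromo, methyl, methoxy or an amine there would raise the number further or fall back level with compound 2. They also leave open whether chloro at another place on the aromatic ring would produce a step of similar size, or any step at all.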